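A few compounds are considered here, and "the series" means these few. Any claim that something is new, unique, unknown or untested is made for them only; others in the source may bear on it.

Compound 1 `N#CC1=C(N)N(c2ccc(S(N)(=O)=O)cc2)C2=C(C(=O)CCC2)C1c1ccc(Cl)cc1Cl` gives 65% in a functional assay on Ehrlich cells (Mus musculus) for cytotoxicity, read by trypan blue exclusion, with a stated time of 2 h, tested at 50 ug/mL; a lower number here means a weaker effect, a higher number a stronger effect of the compound at the concentration tested.
Compound 2 `CCCCNC(=S)NC1=C(C#N)C(c2ccc(Cl)cc2Cl)C2=C(CCCC2=O)N1c1ccc(S(N)(=O)=O)cc1` gives 35% in this assay.
Compound 3 `N#CC1=C(NC(=S)Nc2ccc(Cl)cc2)N(c2ccc(S(N)(=O)=O)cc2)C2=C(C(=O)CCC2)C1c1ccc(Cl)cc1Cl` gives 100% in this assay.

Compound 3 stands highest of the three numbers in this assay; the nearest is compound 1, a number lower by a margin beyond the scatter, and the furthest is compound 2, lower by a still wider margin. Compound 4 `N#CC1=C(NC(N)=O)N(c2ccc(S(N)(=O)=O)cc2)C2=C(C(=O)CCC2)C1c1ccc(Cl)cc1Cl` differs from compound 3 in one place: a group of 3 heavy atoms (1 carbon, 1 nitrogen, 1 oxygen; no ring) in place of a group of 10 heavy atoms (7 carbon, 1 nitrogen, 1 sulfur, 1 chlorine; one six-membered aromatic ring of carbon only), on an amine nitrogen.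

Among the measured compounds shown here, three measured steps bear on this change. The step of a number 35 percentage points higher from compound 1 to compound 3 (beyond the scatter) and the step of a number 65 percentage points higher from compound 2 to compound 3 (beyond the scatter) both tie the highest number to the group that carries the six-membered aromatic ring, which compound 4 loses. The step of a number 30 percentage points lower from compound 1 to compound 2 (beyond the scatter) shows that a group without a ring on the same amine nitrogen fell short of the unsubstituted compound 1. For the measured compounds named here, compound 4 carries the smaller carbamoyl group, so a drop from compound 3 is expected, though its size is uncertain since no measured compound carries a group of this kind. The step expected in this assay is a number 50 percentage points lower from compound 3 to compound 4 (beyond the scatter). For compound 4 the estimate in this assay is 50%, with a range from 25% to 80%.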

Compound 4, a percentage reported as activity, at one concentration (the size of the read-out at that concentration, not a potency): 40%
Beside the measured number, compound 4's estimate is 10 percentage points above it, and the stated range covers the measured number.
By their numbers in this assay, from the lowest: compounds 2 and 4 (each within the scatter of the next); then compound 1; then compound 3.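

In this assay carbamoyl in place of hydrogen on the amine nitrogen gives a number 25 percentage points lower from compound 1 to compound 4 (beyond the scatter) and so joins the group of compound 2 as a second ringless group that falls short of the unsubstituted compound 1. Carbamoyl in place of the group carrying the six-membered aromatic ring gives a number 60 percentage points lower from compound 3 to compound 4 (beyond the scatter) and leaves compound 3 as the only one of the four compounds above compound 1, so among these compounds the gain at this nitrogen appears only with that group. The two ringless groups cannot be told apart, with a number 5 percentage points higher from compound 2 to compound 4 (within the scatter) despite their different sizes in heavy atoms, so these two compounds show no link between the size of a ringless group and the read-out.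

On these data alone, whether the high number of compound 3 belongs to the aromatic ring, its chlorine or the sulfur of that group remains open, and an unsubstituted phenyl or a 4-chlorophenyl on a carbamoyl group would help to separate these. No independent measurement accompanies these numbers to explain the differences.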